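This account rests on a few compounds, and the source may have more. Where it says the series, first, only, none or still open, it means among the compounds named here.

Measured compounds:
compound 1, `COc1ccc(CS(=O)(=O)/C=C/c2ccc(C)cc2C)cc1`: 15000 nM
compound 2, `COc1ccc(CS(=O)(=O)/C=C/c2c(C)cccc2C)cc1`: > 20000 nM

In a functional assay on BT-20 cells (Homo sapiens) for antiproliferative activity, read by trypan blue exclusion (on this read-out lower numbers stand for stronger inhibition and higher numbers for weaker inhibition), compound 1 gives 15000 nM. For compound 2 only a limit is recorded in this assay, > 20000 nM, and this limit is not a number. It is the limit of > 20000 nM in this assay, at which 1 of the 2 values shown sits. Going by the values given here, compound 1 and compound 2 differ in more than one place, so their two values show only that neither compound inhibits strongly on this read-out.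

Compound 3, `COc1ccc(CS(=O)(=O)/C=C/c2c(C)cc(C)cc2C)cc1`, has not yet been measured in this assay. It differs from compound 2 by methyl in place of hydrogen on an aromatic carbon. Among the compounds with values here, since compound 2 stands at the limit, no measured step shows how far such a change moves the read-out. The step expected here, a step that the limit leaves unreadable from compound 2 to compound 3, is none beyond the scatter. The estimate for compound 3 in this assay is 25000 nM, within 10000 nM to 60000 nM, and a further limit rather than a number is quite possible.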

Compound 3, half-maximal inhibitory concentration: > 20000 nM
Compound 3 was reported as a limit (the forecaster's own chance of this, stated with the estimate: 60%); the middle value is on the limit's open side.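

With methyl in place of hydrogen on the aromatic carbon para to a large group, compound 3 in this assay gives > 20000 nM, which is a limit and not a number. Going by these compounds alone, the one step that can be read is an at least 1.3-fold higher number from compound 1 to compound 3 (0.12 log units; that floor lies within the scatter), so this change brings no number lower than the one already measured, though the size of any loss stays unresolved. The step that starts from compound 2 cannot be read, and this methyl does not lift the series off the limit, which now holds most of the values: the limit of > 20000 nM in this assay, at which 2 of the 3 values shown sit.

From the compounds shown here alone, how far past the limit compound 2 and compound 3 lie remains open. Also open, going by these compounds, is whether a different group at this place, such as an amine or a carboxylic acid, would give a value that can be read as a number.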